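Swapping the aryl group on the hydrazone carbon

The source may hold more compounds than are shown below. What is called first, only, known or untested is meant among the compounds shown, and "the series" means these compounds.

Measured compounds:
compound 1 `CN(C)CCn1cnnc1-c1cc(Oc2ccc(NC(=O)N/N=C/c3c(Cl)cccc3Cl)cc2F)ccn1` with 350 nM
compound 2 `COc1ccc(/C=N/NC(=O)Nc2ccc(Oc3ccnc(-c4nncn4CCN(C)C)c3)c(F)c2)c(OC)c1` with 1570 nM

In a functional assay on NCI-H460 cells (Homo sapiens) for cytotoxicity, read by MTT assay, with a stated time of 72 h (a higher number here means a weaker inhibitor, a lower number a stronger inhibitor), compound 2 stands at the higher of the two numbers, the weaker of the pair. Going by the values given here, the only step between the measured compounds is a 4.5-fold higher number from compound 1 to compound 2 (0.65 log units; beyond the scatter), and it lies at the same position that is changed again here. Compound 3 `CN(C)CCn1cnnc1-c1cc(Oc2ccc(NC(=O)N/N=C/c3ccc(O)c(O)c3)cc2F)ccn1` differs from compound 2 as follows: 3,4-dihydroxyphenyl in place of 2,4-dimethoxyphenyl on a carbon with a double bond to nitrogen. Among the compounds with values here, no measured step pairs the 3,4-dihydroxyphenyl group with either of the other aryl groups, so the data say only that exchanging the aryl group on this carbon moved this assay by a modest amount once, without telling which way a further exchange will go. A step of roughly that size in either direction, or none beyond the scatter, is therefore possible, and the estimate for compound 3 is set near compound 2 with a wide range to cover both outcomes: compound 3 is expected to give about 1000 nM, between 250 nM and 4000 nM. This estimate means a step of a 1.6-fold lower number from compound 2 to compound 3 (0.20 log units; within the scatter) is expected.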

Compound 3, half-maximal inhibitory concentration: 1930 nM
Compound 3: middle estimate off by 1.9-fold (0.29 log units), on the low side, within the range that was stated.
By their numbers in this assay, from the lowest: compound 1; then compounds 2 and 3 (each within the scatter of the next).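

In this assay, exchanging 2,4-dimethoxyphenyl for 3,4-dihydroxyphenyl on the carbon with a double bond to nitrogen gives a 1.2-fold higher number from compound 2 to compound 3 (0.09 log units; within the scatter) and so leaves the read-out level within the scatter, even though the entering group brings hydrogen-bond donors and the leaving group has none. Compound 1, with its 2,6-dichlorophenyl group, now stands apart from two different aryl groups instead of one, since a 5.5-fold higher number from compound 1 to compound 3 (0.74 log units; beyond the scatter) joins the earlier 4.5-fold higher number from compound 1 to compound 2 (0.65 log units; beyond the scatter) and makes compound 1 the strongest of the three in this small set. Nothing available here explains why the 2,6-dichlorophenyl group gives the lower number.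

The three compounds leave open whether the lower number of compound 1 depends on chlorine itself or on having two groups placed as they are in 2,6-dichlorophenyl, a question that 2,6-dimethylphenyl or 2-chlorophenyl on the same carbon could help to settle. They also leave open where a plain phenyl group would fall, and so whether the dichlorophenyl group lowers the number or the other two aryl groups raise it.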